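The compounds below may be only part of what the source reports. "The series", "measured", "known", "first", "only" and "open" are said of these compounds alone.

Series notes, a functional assay on BMDM cells (Mus musculus, strain C57BL/6) for inhibition, with a stated time of 2 days; a lower number here means a stronger inhibitor, a higher number a weaker inhibitor.

Compound 2 `Cc1csc(NC(=O)Cn2cc(-c3ccccc3Cl)nn2)n1` gives 1240 nM in this assay; compound 1 `CCOC(=O)c1sc(NC(=O)Cn2cc(-c3ccc(OC)cc3)nn2)nc1C` gives 2330 nM, within the scatter of compound 2. Compound 3 `Cc1cc(NC(=O)Cn2cc(-c3ccccc3Cl)nn2)no1` returns only a limit, > 30000 nM, which counts as a limit of this assay the limit of > 30000 nM in this assay, at which 1 of the 3 values shown sits, and not as a number. Going by the values given here, the one measured step, an at least 24-fold higher number from compound 2 to compound 3 (1.38 log units; beyond the scatter), is large, but it concerns the ring on the amide-type nitrogen, which is kept unchanged in compound 4.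

Compound 4 `Cc1csc(NC(=O)Cn2cc(-c3cccs3)nn2)n1` differs from compound 2 only at the aryl on the triazole: thiophen-2-yl in place of 2-chlorophenyl on an aromatic carbon. Among the compounds with values here, no measured pair changes this position alone; compound 1 and compound 2 differ there as well as in the core, so their two values show only that both fall within the scatter of each other. The change from compound 2 to compound 4 is therefore expected to give no step beyond the scatter, estimated as a 1.5-fold higher number from compound 2 to compound 4 (0.16 log units; within the scatter).

Compound 4 is expected to give about 1800 nM in this assay, estimated between 600 nM and 6000 nM.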

Compound 4, half-maximal inhibitory concentration: 40 nM
Compound 4: middle estimate off by 45-fold (1.65 log units), on the high side; the whole stated range lies above it.
By their numbers in this assay, from the lowest: compound 4; then compounds 2 and 1 (each within the scatter of the next). At a limit, above all of these: compound 3.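

In this assay the aromatic carbon of the five-membered ring with 3 nitrogen turns out to be a sensitive position: the change to thiophen-2-yl gives a 31-fold lower number from compound 2 to compound 4 (1.49 log units; beyond the scatter) and is a large step beyond the scatter. Going by these compounds alone, until now, the only large measured step lay at the ring on the amide-type nitrogen, so this is the first sign that the aryl group also strongly sets the number, here towards a lower one. Nothing shown bears on the cause of this step.

Within the data shown here, the single pair cannot separate the loss of the chlorine from the change of ring, and a plain phenyl, thiophen-3-yl or furan-2-yl at this carbon would help to tell these apart. From the compounds shown here alone, it also remains open whether thiophen-2-yl keeps this effect with the ethyl ester core of compound 1.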